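Aryl swaps on the aromatic-ring nitrogen of the shared core

This account rests on a few compounds, and the source may have more. Where it says the series, first, only, none or still open, it means among the compounds named here.

Among the compounds with values here, compound 2 `COc1cccc(Nc2nc(-c3ccncc3)nc3c2CC(N)CC3)c1` gives 8800 nM in a functional assay on DU-145 cells (Homo sapiens) for antiproliferative activity, read by MTT assay, with a stated time of 72 h (a lower number here means a stronger inhibitor, a higher number a weaker inhibitor), and stands at the low end of the two numbers so far, though its gap to compound 1 is within the scatter. Compound 1 `CN(C)c1ccc(Nc2nc(-c3ccncc3)nc3c2CC(N)CC3)cc1` gives 11500 nM in this assay; the step of a 1.3-fold lower number from compound 1 to compound 2 (0.12 log units; within the scatter) exchanged one aryl group for another on the same nitrogen and stayed within the scatter. Compound 3 `NC1CCc2nc(-c3ccncc3)nc(Nc3ccc(F)cc3)c2C1` makes a further exchange at that position: 4-fluorophenyl in place of 3-methoxyphenyl on a nitrogen on an aromatic ring. Within the data shown here, the only measured step that bears on this change, a 1.3-fold lower number from compound 1 to compound 2 (0.12 log units; within the scatter), moved the number by no more than the scatter, so no step beyond the scatter is expected here in either direction. The expected step for compound 3 is therefore a 1.0-fold higher number from compound 2 to compound 3 (0.01 log units; within the scatter). Compound 3 is estimated at 9000 nM in this assay, with a range from 3000 nM to 27000 nM.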

Compound 3, half-maximal inhibitory concentration in the DU-145 assay: 10500 nM
Compound 3: middle estimate off by 1.2-fold (0.07 log units), on the low side; measured number inside the range.
By their numbers in the DU-145 assay, from the lowest: compounds 2, 3 and 1 (each within the scatter of the next).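

In the DU-145 assay the third aryl group on this nitrogen again stays within the scatter (a 1.2-fold higher number from compound 2 to compound 3 (0.08 log units; within the scatter); a 1.1-fold lower number from compound 1 to compound 3 (0.04 log units; within the scatter)), so 4-fluorophenyl, 3-methoxyphenyl and the 4-(dimethylamino)phenyl of compound 1 cannot be told apart at this position. In a physicochemical assay for solubility, read by HPLC, in phosphate buffer, measured as kinetic solubility, with a stated time of 24 h, at pH 7.4 (a higher number here means a more soluble compound, a lower number a less soluble compound), compound 2 gives > 250000 nM as a limit of the assay and not a number. In the physicochemical assay compound 3 gives > 250000 nM as a limit of the assay and not a number.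

From the compounds shown here alone, whether an amine, a carboxylic acid or a longer chain on this aryl ring would move the number in the DU-145 assay beyond the scatter stays open. The step from compound 2 to compound 3 in the physicochemical assay cannot be read because both values are limits: the limit of > 250000 nM in the physicochemical assay, at which 2 of the 2 values shown sit.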